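The compounds below may be only part of what the source reports. "The series", "measured", "known", "first", "only" and "open" are said of these compounds alone.

Measured in an ADME assay on cells (Homo sapiens) for cytotoxicity, read by resazurin assay, with a stated time of 5 days; a lower number here means that less compound is tolerated, a higher number that more compound is tolerated:
- Compound 1 `COc1ccc(-c2nc(CS(=O)(=O)c3cccc(Cl)c3)nc3ccsc23)cc1`: 69000 nM
- Compound 2 `O=S(=O)(Cc1nc(-c2cccnc2)c2sccc2n1)c1cccc(Cl)c1`: > 50000 nM (a limit)

Compound 2 gives > 50000 nM, which is a limit of the assay and not a number, so it has only a bound in this assay.

Compound 3 `COc1ccc(Oc2nc(CS(=O)(=O)c3cccc(Cl)c3)nc3ccsc23)cc1` is reached from compound 2 by one change: 4-methoxyphenoxy in place of pyridin-3-yl on an aromatic carbon. This places 4-methoxyphenoxy in place of pyridin-3-yl on an aromatic carbon next to the ring nitrogen.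

Among the compounds with values here, the one measured step is a step that the limit leaves unreadable from compound 1 to compound 2. It offers no size to carry over because of the limit of > 50000 nM in this assay, at which 1 of the 2 values shown sits. Within the data shown here, the only number therefore comes from compound 1, which carries 4-methoxyphenyl and gives 69000 nM, and the expectation leans on that value. The entering group has not been measured at this place, so only a modest move is expected in this assay, towards lower numbers if there is any move at all.

The estimated step is an at least 1.1-fold lower number from compound 2 to compound 3 (0.04 log units; that floor lies within the scatter), and a reading that is again only a limit remains quite possible.

For compound 3 the expected value is 45000 nM, with an estimated range from 15000 nM to 100000 nM.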

Compound 3, half-maximal cytotoxic concentration: > 50000 nM
Compound 3: only a limit was reported; the forecaster's own chance of this, stated with the estimate: 40%; middle value at least 1.1-fold (0.04 log units) away from the limit.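

In this assay compound 3 gives > 50000 nM, which is a limit of the assay and not a number. No new step can be read between compound 3 and either compound 1 or compound 2, because the comparison rests on limits: the limit of > 50000 nM in this assay, at which 2 of the 3 values shown sit. The compounds shown leave open how far 4-methoxyphenoxy, pyridin-3-yl and 4-methoxyphenyl differ at this place.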